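A few compounds are considered here, and "the series" means these few. Any claim that something is new, unique, unknown or untested is made for them only; others in the source may bear on it.

Working notes on the series. Two compounds have numbers in a functional assay on CHOK cells for antagonist activity at growth hormone secretagogue receptor type 1 (Homo sapiens), read by calcium flux; on this read-out lower numbers stand for stronger inhibition and higher numbers for weaker inhibition. Compound 1 `CCc1nc(N)nc(N)c1-c1ccc(NCc2cc(F)c(S(C)(=O)=O)c(F)c2)cc1` gives 45 nM in this assay. Compound 2 `Nc1nc(N)c(-c2ccc(NCc3csc(Cl)c3)cc2)c(COCc2ccccc2)n1` gives 170 nM in this assay, which is the higher of the two numbers; the gap between compound 2 and compound 1 lies beyond the usual scatter, so compound 2 is the weaker of the two measured. Compound 1 and compound 2 differ in more than one place, so nothing can be read from that pair about any single change.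

Compound 3 `Nc1nc(N)c(-c2ccc(NCc3cnc4ccccc4c3)cc2)c(COCc2ccccc2)n1` has not been measured. It departs from compound 2 in one place: quinolin-3-yl in place of 5-chlorothiophen-3-yl on a saturated chain carbon bound to a nitrogen on an aromatic ring. Going by the values given here, no measured pair isolates this change, so the size and direction of the step have to be guessed without a precedent of the same kind. Among the compounds with values here, the replacement swaps a five-membered ring bearing chlorine for a two-ring system; nothing among the measured compounds says whether that helps or hurts in this assay. The expectation is a step of a 1.1-fold lower number from compound 2 to compound 3 (0.05 log units; within the scatter), that is, no change beyond the scatter, held loosely. Compound 3 is therefore estimated at 150 nM in this assay, within a range of 40 nM to 600 nM.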

Compound 3, half-maximal inhibitory concentration: 780 nM
Compound 3: middle estimate off by 5.2-fold (0.72 log units), on the low side; measured number above the stated range.
By their numbers in this assay, from the lowest: compound 1; then compound 2; then compound 3.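

On a saturated chain carbon bound to a nitrogen on an aromatic ring, this assay responds to the identity of the ring: quinolin-3-yl in place of 5-chlorothiophen-3-yl gives a 4.6-fold higher number from compound 2 to compound 3 (0.66 log units; beyond the scatter). Going by these compounds alone, this is the only single-place step so far, and it shows that this position is not indifferent to the change, with the two-ring quinolin-3-yl of 10 heavy atoms on the weaker side of the pair and the 5-chlorothiophen-3-yl of 6 heavy atoms on the stronger side. No measurement at hand accounts for the size or direction of this step.

The compounds shown leave open whether the higher number goes with the second ring or with the ring nitrogen of quinolin-3-yl, and a pyridin-3-yl or a naphthalen-2-yl group at this place would separate the two. Also open, as far as these compounds go, is whether the same change would give a step of like size on the core of compound 1, which differs from compound 2 in more than one place.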